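The source may report more compounds than this note shows. Statements on the series, on what has been measured and on what is new or still open speak of the compounds shown alone.

Measured compounds:
compound 1, `Cc1cc(C)cc(SCc2ccc(C(=O)Nc3ccccc3N)cc2)c1`: 78.5%
compound 2, `CCc1ccc(SCc2ccc(C(=O)Nc3ccccc3N)cc2)cc1`: 91.4%
compound 3, `Nc1ccccc1NC(=O)c1ccc(CSc2ccc(Cl)cc2)cc1`: 50.4%

All three share one core and differ only in the aryl group on the sulfur. In a functional assay on A549 cells (Homo sapiens) for inhibition, read by CCK-8 assay, with a stated time of 72 h, tested at 8 uM (on this read-out higher numbers stand for more inhibition of growth at the one concentration tested and lower numbers for less inhibition of growth), compound 3 gives 50.4%, the lowest of the three numbers. Compound 1 gives 78.5% and compound 2 gives 91.4%; the steps of a number 28.1 percentage points lower from compound 1 to compound 3 (beyond the scatter) and a number 41 percentage points lower from compound 2 to compound 3 (beyond the scatter) both lie beyond the scatter, as does a number 12.9 percentage points higher from compound 1 to compound 2 (beyond the scatter).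

Compound 4, `Nc1ccccc1NC(=O)c1ccc(CSCCc2ccccc2)cc1`, is not yet measured. It differs from compound 3 in one place: phenethyl in place of 4-chlorophenyl on a sulfur. Going by the values given here, the change replaces the aryl on the sulfur with a chain carrying a phenyl ring, so none of the measured steps matches it directly; the three steps only exchange one aryl for another on the same sulfur. What they do show is that the two compounds whose sulfur substituents are carbon only, compound 1 and compound 2, sit higher than compound 3, and that moving away from 4-chlorophenyl was tied to the larger numbers in both cases. On that thin basis a rise beyond the scatter is expected for compound 4, of modest size: a number 17.6 percentage points higher from compound 3 to compound 4 (beyond the scatter). Among the compounds with values here, compound 4 is estimated at 68%, with a range from 45% to 90%, the width reflecting that a phenethyl on this sulfur has no precedent among the measured compounds.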

Compound 4, percent growth inhibition at one concentration: 84.1%
Compound 4: middle estimate off by 16.1 percentage points, on the low side; the range from low to high includes it.
By their numbers in this assay, from the lowest: compound 3; then compounds 1, 4 and 2 (each within the scatter of the next, the first and the last beyond it).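

In this assay, the step of a number 33.7 percentage points higher from compound 3 to compound 4 (beyond the scatter) shows that this sulfur can carry a phenyl ring on a chain as well as an aryl group, and that phenethyl stands well clear of 4-chlorophenyl. Phenethyl also gives no separation from either carbon-only aryl group, with a number 7.3 percentage points lower from compound 2 to compound 4 (within the scatter) and a number 5.6 percentage points higher from compound 1 to compound 4 (within the scatter), so the added chain shows no clear cost or gain against those two, although they remain apart from each other by a number 12.9 percentage points higher from compound 1 to compound 2 (beyond the scatter). Going by these compounds alone, compound 3, the only chlorine-bearing compound here, now sits apart from all three others, but no supporting data explain this separation or the recovery with phenethyl.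

The compounds shown leave open whether the low number follows the chloro group itself or 4-chlorophenyl as a whole, which a 2-(4-chlorophenyl)ethyl group on the same sulfur would help separate. They also leave open how far the chain can be changed, as with benzyl or 3-phenylpropyl, and whether a ring bearing an amine or a carboxylic acid fits this place.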